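The compounds below may be only part of what the source reports. "The series", "measured", "known", "first", "only" and "open" are said of these compounds alone.

Of the compounds shown here, two have been measured in an assay on HEK293 cells for inhibition of N-acylethanolamine-hydrolyzing acid amidase (Homo sapiens), read by scintillation counting, tested at 50 uM; a higher number here means more inhibition at the concentration tested (going by the name of the read-out), a lower number less inhibition. Compound 1 `CCCCCCCCCCCCCCCC(=O)Nc1ccc([N+](=O)[O-])cc1` gives 15%. Compound 2 `CCCCCCCCCCCCCCCCNC(=O)C1CCCC1` gives 8%. Compound 2 stands at one end of the two numbers, compound 1 at the other, and the gap between them lies within the usual scatter, so the two cannot be told apart.

Compound 3 `CCCCCCCCCCCCCCCCNC(=O)c1ccc([N+](=O)[O-])cc1` differs from compound 2 in one place: 4-nitrophenyl in place of cyclopentyl on a carbonyl carbon. Among the measured compounds shown here, no measured pair shows this change, so the step is expected to be small, in either direction, and likely not beyond the scatter. Compound 3 is estimated at 12%, between 0% and 30%, an expected step of a number 4 percentage points higher from compound 2 to compound 3 (within the scatter).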

Compound 3, a percentage reported as inhibition, at one concentration (the size of the read-out at that concentration, not a potency): 4%
Beside the measured number, compound 3's estimate is 8 percentage points above it; the measured number falls inside the stated range.
By their numbers in this assay, from the lowest: compounds 3, 2 and 1 (each within the scatter of the next, the first and the last beyond it).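

In this assay, putting 4-nitrophenyl in place of cyclopentyl on a carbonyl carbon gives a number 4 percentage points lower from compound 2 to compound 3 (within the scatter). At this position, then, a larger aromatic group that brings hydrogen-bond acceptors cannot be told apart from a smaller non-aromatic ring of carbon only. No supporting measurement bears on the reason for this result. Still open, going by these compounds, is whether an amine or a carboxylic acid in place of 4-nitrophenyl, or a shorter chain on the amide-type nitrogen, would move the number beyond the scatter.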